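The source may report more compounds than this note shows. Statements on the series, on what has been measured and on what is new or still open speak of the compounds shown alone.

Compound 1 `Cn1c(Cc2nn(C)c(=O)c3ccccc23)nnc1SCCCCCCCC(=O)Nc1ccc(Cl)cc1Cl` is tested in an assay on isolated protein (Mus musculus) for inhibition of IL15-IL15 receptor (Homo sapiens), read by resazurin assay, with stated times of 30 min and 2.5 days (on this read-out lower numbers stand for stronger inhibition and higher numbers for weaker inhibition), where compound 1 gives 1900 nM. Among the two compounds with a number, compound 1 has the lowest, and compound 3 `Cn1c(Cc2nn(C)c(=O)c3ccccc23)nnc1SCCCCCCCCCC(=O)Nc1ccc(Cl)cc1Cl`, with 2300 nM, lies within the scatter of it. Compound 2 `Cn1c(Cc2nn(C)c(=O)c3ccccc23)nnc1SCC(=O)Nc1ccc(I)cc1` is reported in this assay only as "not active" (no number reported), without a number. Compound 4 `Cn1c(Cc2nn(C)c(=O)c3ccccc23)nnc1SCCCCCCCC(=O)Nc1ccc(O)cc1` is not yet measured in this assay. Compound 4 differs from compound 1 in one place: 4-hydroxyphenyl in place of 2,4-dichlorophenyl on an amide-type nitrogen. Within the data shown here, no measured pair shows this change, so its effect is unknown; since compound 2, which also lacks the 2,4-dichlorophenyl, gives "not active" (no number reported), a step towards weaker inhibition is expected, namely a 2.6-fold higher number from compound 1 to compound 4 (0.42 log units; beyond the scatter). Compound 4 is therefore estimated at 5000 nM, in the range 1500 nM to 20000 nM.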

Compound 4, half-maximal inhibitory concentration: > 30000 nM
Compound 4: no number, only a limit (the forecaster's own chance of this, stated with the estimate: 30%); at least 6.0-fold (0.77 log units) between middle value and limit.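

Among these compounds, the one change at this position, 4-hydroxyphenyl in place of 2,4-dichlorophenyl on an amide-type nitrogen with the rest of the molecule kept, gives an at least 15-fold higher number from compound 1 to compound 4 (1.19 log units; beyond the scatter) in this assay. So inhibition here depends strongly on what sits on this nitrogen. For compound 4, > 30000 nM is a limit of the assay and not a number, and the size of the step rests on it: the limit of > 30000 nM in this assay, at which 1 of the 4 values shown sits.

The compounds shown do not separate the loss of the two chlorines from the gain of the hydroxyl. A 4-chlorophenyl or 4-methoxyphenyl on the same nitrogen would speak to that.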